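Notes on the step to compound 3

The source may report more compounds than this note shows. Statements on the series, on what has been measured and on what is new or still open speak of the compounds shown alone.

Compound 1 `COc1ccc([C@H]2CC(=O)N(c3cccnc3)C2)cc1OC1CCCC1`: > 10000 nM (a limit)
Compound 2 `COc1ccc([C@H]2CC(=O)N(c3ccc([S+](C)[O-])cc3)C2)cc1OC1CCCC1`: 7510 nM
Compound 3 `COc1ccc([C@H]2CC(=O)N(c3ccc(S(C)(=O)=O)cc3)C2)cc1OC1CCCC1`: not yet measured

In a functional assay on HEK293 cells (Homo sapiens) for cytotoxicity (a lower number here means that less compound is tolerated, a higher number that more compound is tolerated), compound 1 gives > 10000 nM, which is a limit and not a number. Going by the values given here, compound 2 gives 7510 nM, the only actual number so far. The step to compound 3 is a group of 4 heavy atoms (1 carbon, 2 oxygen, 1 sulfur; no ring) in place of a group of 3 heavy atoms (1 carbon, 1 oxygen, 1 sulfur; no ring), on an aromatic carbon.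

Among the compounds with values here, the only measured step is an at least 1.3-fold lower number from compound 1 to compound 2 (0.12 log units; that floor lies within the scatter). It exchanges the whole aromatic group on the amide-type nitrogen in a ring, whereas the new change falls on an aromatic carbon, so it gives no direct size for this change. No step beyond the scatter is therefore expected in this assay, and no direction is favoured. The expected step is a 1.2-fold higher number from compound 2 to compound 3 (0.08 log units; within the scatter). For compound 3 the estimated value is 9000 nM, with an expected range of 3500 nM to 20000 nM.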

Compound 3, half-maximal cytotoxic concentration: > 10000 nM
Compound 3 ended at the assay's limit; the forecaster's own chance of this, stated with the estimate: 45%; at least 1.1-fold (0.04 log units) between middle value and limit.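

The change at this position now has its own reading in this assay: an at least 1.3-fold higher number from compound 2 to compound 3 (0.12 log units; that floor lies within the scatter). Going by these compounds alone, exchanging the group on this aromatic carbon, para to a large group, for methylsulfonyl therefore gives no step that can be placed beyond the scatter. Compound 3 gives > 10000 nM, which is a limit, and the step from compound 1 to compound 3 cannot be read, leaving little of the series open to comparison: the limit of > 10000 nM in this assay, at which 2 of the 3 values shown sit.

Still open, as far as these compounds go, is whether an amine or a carboxylic acid on the same aromatic carbon would give an actual number in this assay rather than a limit. Also open, from the compounds shown here alone, is the real distance between compound 2 and compound 3, which the printed floor does not fix.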